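Moving the Ether Group to a Different Aryl Amide

This account rests on a few compounds, and the source may have more. Where it says the series, first, only, none or still open, it means among the compounds named here.

Compound 3, `COc1ccc2c(=O)c(/C=C/C(=O)Nc3ccccc3OC)coc2c1`, carries a 2-methoxyphenyl on its amide-type nitrogen. In a functional assay on A549 cells (Homo sapiens) for inhibition, read by MTT assay, with a stated time of 48 h (on this read-out higher numbers stand for weaker inhibition and lower numbers for stronger inhibition), compound 3 gives > 100000 nM, which is a limit of the assay rather than a number. Its closest measured neighbour is compound 2, `COc1ccc(CNC(=O)/C=C/c2coc3cc(OC)ccc3c2=O)cc1`, which has a 4-methoxybenzyl in the same place; in this assay compound 2 gives 22500 nM. The step of an at least 4.4-fold higher number from compound 2 to compound 3 (0.64 log units; beyond the scatter) can only be read as a bound, because the limit of > 100000 nM in this assay, at which 2 of the 3 values shown sit, caps what the assay reports. Compound 1, `COc1ccc2c(=O)c(/C=C/C(=O)NCc3ccc(F)cc3)coc2c1`, bears a 4-fluorobenzyl there. In this assay compound 1 gives > 100000 nM, again a limit. The step of an at least 4.4-fold lower number from compound 1 to compound 2 (0.64 log units; beyond the scatter) favours methoxy over fluoro on that ring, while a step that the two limits leave unreadable from compound 1 to compound 3 cannot be sized since both ends are limits.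

Compound 4, `CCOc1ccc(NC(=O)/C=C/c2coc3cc(OC)ccc3c2=O)cc1`, differs from compound 3 in one place: 4-ethoxyphenyl in place of 2-methoxyphenyl on an amide-type nitrogen. Among the measured compounds shown here, no measured step matches this exact change. For the measured compounds named here, the one step that bears on it, an at least 4.4-fold higher number from compound 2 to compound 3 (0.64 log units; beyond the scatter), moved toward weaker inhibition when the 4-methoxybenzyl gave way to the 2-methoxyphenyl, and compound 4 brings back an ether on the 4-ethoxyphenyl, as compound 2 has on its 4-methoxybenzyl. Compound 4 is therefore expected to come in around 50000 nM, within 12000 nM to 200000 nM. That expectation means a step of an at least 2.0-fold lower number from compound 3 to compound 4 (0.30 log units; that floor lies within the scatter) toward stronger inhibition, though another limit remains quite possible.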

Compound 4, half-maximal inhibitory concentration: > 100000 nM
Compound 4: only a limit was reported (the forecaster's own chance of this, stated with the estimate: 50%); middle value at least 2.0-fold (0.30 log units) from the limit.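

Swapping the 4-methoxybenzyl for a 4-ethoxyphenyl on the amide-type nitrogen gives an at least 4.4-fold higher number from compound 2 to compound 4 (0.64 log units; beyond the scatter), so an ether on a phenyl attached directly to that nitrogen did not restore a readable value in this assay, whether it was the 2-methoxyphenyl or the 4-ethoxyphenyl. Among the compounds shown, a measured number remains confined to the one with the 4-methoxybenzyl, while the 4-fluorobenzyl and both ether-bearing phenyl groups give only limits. The steps among compound 1, compound 3 and compound 4 cannot be read, because each of these compounds stops at the same cap: the limit of > 100000 nM in this assay, at which 3 of the 4 values shown sit.

Still open, on these data alone, is whether the 4-ethoxyphenyl falls short through its ethoxy chain or through the missing benzyl carbon, a question that a 4-methoxyphenyl or a 4-ethoxybenzyl on the same nitrogen would address. As far as these compounds go, it is also open whether an amine or a carboxylic acid on that ring, in place of the ether, would give a readable value in this assay.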